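A few compounds are considered here, and "the series" means these few. Any claim that something is new, unique, unknown or untested is made for them only; others in the source may bear on it.

Compound 1 `CN(C)CCn1cnnc1-c1cc(Oc2ccc(NC(=O)N/N=C/c3ccc(Cl)cc3)cc2F)ccn1`: 780 nM
Compound 2 `CN(C)CCn1cnnc1-c1cc(Oc2ccc(NC(=O)N/N=C/c3ccc(O)cc3)cc2F)ccn1`: 3560 nM

In a functional assay on A549 cells (Homo sapiens) for cytotoxicity, read by MTT assay, with a stated time of 72 h (on this read-out higher numbers stand for weaker inhibition and lower numbers for stronger inhibition), compound 2 stands at the highest of the two numbers. Going by the values given here, the only measured step, a 4.6-fold higher number from compound 1 to compound 2 (0.66 log units; beyond the scatter), concerns a different change and does not bear on what follows. Compound 3 `CN(C)CCn1cnnc1-c1cc(Oc2ccc(NC(=O)N/N=C/c3cccc(O)c3)cc2F)ccn1` differs from compound 2 by 3-hydroxyphenyl in place of 4-hydroxyphenyl on a carbon with a double bond to nitrogen. Among the compounds with values here, no measured pair shows what moving the hydroxy group to another ring position does, so no step beyond the scatter is expected in this assay. Compound 3 is therefore estimated at 3500 nM, with a range from 1200 nM to 10000 nM. The expected step is a 1.0-fold lower number from compound 2 to compound 3 (0.01 log units; within the scatter).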

Compound 3, half-maximal inhibitory concentration: > 100000 nM
Compound 3: only a limit was reported (the forecaster's own chance of this, stated with the estimate: 5%); middle value at least 28-fold (1.45 log units) away from the limit.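

Moving the hydroxy group, with the same atoms joined differently, carries a large penalty on the carbon with a double bond to nitrogen: in this assay 3-hydroxyphenyl in place of 4-hydroxyphenyl gives an at least 28-fold higher number from compound 2 to compound 3 (1.44 log units; beyond the scatter), so ring position matters here as much as the identity of the group. Set against 4-chlorophenyl, the same ring gives an at least 120-fold higher number from compound 1 to compound 3 (2.10 log units; beyond the scatter), a larger step than the earlier change of chloro to hydroxy. Compound 3 is reported only as a limit: the limit of > 100000 nM in this assay, at which 1 of the 3 values shown sits.

The compounds shown leave open whether 3-chlorophenyl, 3-methoxyphenyl or 3-aminophenyl on that carbon would lose as much as 3-hydroxyphenyl.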